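Phenyl for propyl on the core of compound 2

A few compounds are considered here, and "the series" means these few. Any claim that something is new, unique, unknown or untested is made for them only; others in the source may bear on it.

Compound 2 is `CCCc1cc2cn(C3CC(CO)N(C)O3)c(=O)nc2o1`. In an ADME assay on MRC5 cells (Homo sapiens) for cytotoxicity, read by microscopy, with a stated time of 96 h (on this read-out higher numbers stand for lower toxicity in this test and lower numbers for higher toxicity in this test), compound 2 gives > 250000 nM, a limit of the assay rather than a number. Compound 1 is `CN1OC(n2cc3ccoc3nc2=O)CC1CO`, differing by propyl in place of hydrogen on an aromatic carbon. In this assay compound 1 gives > 250000 nM, likewise a limit. The step that the two limits leave unreadable from compound 1 to compound 2 cannot be sized, since both values sit at the limit of > 250000 nM in this assay, at which 2 of the 2 values shown sit. Compound 3 is `CN1OC(n2cc3cc(-c4ccccc4)oc3nc2=O)CC1CO`, with phenyl in place of propyl on an aromatic carbon. No readable measured step bears on this change. The step of a number no higher from compound 2 to compound 3 (the limit leaves the size open) is expected to show nothing beyond the scatter, most likely another limit. For compound 3 the estimate is 250000 nM, within 80000 nM to 500000 nM.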

Compound 3, minimum cytotoxic concentration: > 250000 nM
Compound 3: a limit, no number; the forecaster's own chance of this, stated with the estimate: 75%; the middle value sits exactly at the limit.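

No step among compound 1, compound 2 and compound 3 can be read in this assay, as each gives only a limit: the limit of > 250000 nM in this assay, at which 3 of the 3 values shown sit.

The compounds shown leave open whether hydrogen, propyl and phenyl on the shared core differ at all in this assay.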